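Adding a Methyl to a Saturated Chain on Two Cores

The source may report more compounds than this note shows. Statements on the series, on what has been measured and on what is new or still open speak of the compounds shown alone.

Compound 1 `CCc1cn([C@H]2C[C@@H]3OP(=O)(O)OC[C@H]3O2)c(=O)[nH]c1=O` gives 60 ug/mL in a functional assay on Raji cells (Homo sapiens); a lower number here means a stronger inhibitor, a higher number a weaker inhibitor. Compound 3 `CCCc1cn([C@H]2C[C@@H]3OP(=O)(O)OC[C@H]3O2)c(=O)[nH]c1=O` differs from compound 1 by methyl in place of hydrogen on a saturated chain carbon, two bonds along the chain from an aromatic carbon; in this assay compound 3 reaches only a limit, > 500 ug/mL. The step is an at least 8.3-fold higher number from compound 1 to compound 3 (0.92 log units; beyond the scatter). Compound 2 `CCCCc1cn([C@H]2C[C@H](O)[C@@H](CO)O2)c(=O)[nH]c1=O` has a core whose difference from compound 1 is not broken down here; in this assay compound 2 also reaches only a limit, > 500 ug/mL. Notably, (the limit of > 500 ug/mL in this assay, at which 2 of the 3 values shown sit).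

Compound 4 `CCCCCc1cn([C@H]2C[C@H](O)[C@@H](CO)O2)c(=O)[nH]c1=O` differs from compound 2 by methyl in place of hydrogen on a saturated chain carbon, four bonds along the chain from an aromatic carbon. This is the same kind of change as from compound 1 to compound 3, though here the added methyl sits four bonds along the chain from an aromatic carbon rather than two. The expected step is a step that the limit leaves unreadable from compound 2 to compound 4, resting on the limit of compound 2 at > 500 ug/mL and on the step of an at least 8.3-fold higher number from compound 1 to compound 3 (0.92 log units; beyond the scatter), which weakened rather than strengthened inhibition. Compound 4 is therefore estimated at 1500 ug/mL, most likely again reported only as a limit.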

Compound 4, concentration for 50% inhibition: 334 ug/mL
Compound 4: the middle estimate sits 4.5-fold (0.65 log units) above what was measured, outside the stated range (below it).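

In this assay, the same change did not carry over from the core of compound 1 to the core of compound 2 with the same result: the same change on two cores in this assay, an at least 8.3-fold higher number (0.92 log units; beyond the scatter) from compound 1 to compound 3 and an at least 1.4-fold lower number (0.17 log units; that floor lies within the scatter) from compound 2 to compound 4, at least 12-fold (1.09 log units) apart, beyond the scatter of two such steps. The new step reads an at least 1.4-fold lower number from compound 2 to compound 4 (0.17 log units; that floor lies within the scatter), so it does not on its own establish a gain on this core. Nor does the gap show whether the core or the place of the methyl, two bonds along the chain in one case and four in the other, decides the outcome, and the steps rest on limits rather than numbers: the limit of > 500 ug/mL in this assay, at which 2 of the 4 values shown sit.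

The compounds shown leave open how a longer chain such as hexyl would read on either core. As far as these compounds go, it also remains open whether a chain ending in an amine or a carboxylic acid would follow the same course.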